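Replacing 2,4-dichlorophenyl: what growth inhibition might show

This account rests on a few compounds, and the source may have more. Where it says the series, first, only, none or still open, it means among the compounds named here.

Compound 1 `O=S(=O)(/C=C/c1ccc(Cl)c(Cl)c1)Cc1ccc(Nc2ncnc3ccc(Br)cc23)cc1`: 5000 nM
Compound 2 `O=S(=O)(/C=C/c1ccc(Cl)cc1Cl)Cc1ccc(Nc2ncnc3ccc(Br)cc23)cc1`: > 100000 nM (a limit)

Both compounds were tested in a functional assay on SW-620 cells (Homo sapiens); on this read-out lower numbers stand for stronger inhibition of growth and higher numbers for weaker inhibition of growth. Compound 2 has no number on this read-out, only (the limit of > 100000 nM in this assay, at which 1 of the 2 values shown sits). The next compound to be measured is compound 3 `O=S(=O)(/C=C/c1ccc(C(F)(F)F)cc1F)Cc1ccc(Nc2ncnc3ccc(Br)cc23)cc1`, and the change from compound 2 is 2-fluoro-4-(trifluoromethyl)phenyl in place of 2,4-dichlorophenyl on a double-bonded chain carbon bound to a double-bonded chain carbon.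

Going by the values given here, one measured step bears on this place: an at least 20-fold higher number from compound 1 to compound 2 (1.30 log units; beyond the scatter). This large step, beyond the scatter, shows that the choice of aryl group on this chain can matter greatly. It involves two chlorinated groups, however, and says nothing directly about fluorine or trifluoromethyl. The entering group is numbered like the 2,4-dichlorophenyl of compound 2, not like the 3,4-dichlorophenyl of compound 1, which gives 5000 nM. In this assay, therefore, only a modest step towards a lower number is expected, and another limit would be no surprise. For compound 3 the estimated value is 60000 nM, with an expected range from 10000 nM to 200000 nM. The expected step is an at least 1.6-fold lower number from compound 2 to compound 3 (0.22 log units; that floor lies within the scatter).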

Compound 3, concentration for 50% growth inhibition: 55000 nM
For compound 3 the middle estimate is 1.1-fold (0.04 log units) above the measured one; the range from low to high includes it.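

In this assay, the exchange of 2,4-dichlorophenyl for 2-fluoro-4-(trifluoromethyl)phenyl turns a result without a number into a measured one, and the step is an at least 1.8-fold lower number from compound 2 to compound 3 (0.25 log units; that floor lies within the scatter); the data therefore fix only a floor for this change, not its full size. The entering group does not match the 3,4-dichlorophenyl group, as the second comparison is an 11-fold higher number from compound 1 to compound 3 (1.04 log units; beyond the scatter), so among these three compounds both 2,4-dichlorophenyl and 2-fluoro-4-(trifluoromethyl)phenyl give higher numbers than 3,4-dichlorophenyl on the double-bonded chain carbon, and none of the three goes against this. Compound 2 has a limit in place of a number: the limit of > 100000 nM in this assay, at which 1 of the 3 values shown sits.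

Both the halogen on one side of the ring and the group on the other differ in this exchange, so what fluorine and trifluoromethyl each contribute cannot be separated from these compounds. Going by these compounds, how an unsubstituted phenyl group or a methoxyphenyl group would behave at this place, and whether any group here could give a lower number than compound 1 does, remains open.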